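Shifting the Ring Nitrogen from Pyridin-4-yl to Pyridin-3-yl

The compounds below may be only part of what the source reports. "The series", "measured", "known", "first", "only" and "open" are said of these compounds alone.

Measured compounds:
compound 1 `CC(=O)c1sc(NC(C)C)c(C#N)c1N`: > 5000 nM
compound 2 `COc1ccc(C(=O)c2sc(NC(C)C)c(C#N)c2N)cc1OC`: 1770 nM
compound 3 `CC(C)Nc1sc(C(=O)c2ccncc2)c(N)c1C#N`: > 5000 nM

In an assay for inhibition of Maternal embryonic leucine zipper kinase (Homo sapiens), read by ADP-Glo, with a stated time of 0.5 h (on this read-out higher numbers stand for weaker inhibition and lower numbers for stronger inhibition), compound 3 gives only a limit of the assay, > 5000 nM, and not a number. Compound 1 likewise reaches only the limit > 5000 nM in this assay. Among the measured compounds shown here, compound 2 is the one compound of the three with a number, 1770 nM in this assay. For the measured compounds named here, the single measured step that changes the group on the carbonyl carbon, a step that the two limits leave unreadable from compound 1 to compound 3, is left unreadable because the limit of > 5000 nM in this assay, at which 2 of the 3 values shown sit, sets both of its ends. Compound 4 `CC(C)Nc1sc(C(=O)c2cccnc2)c(N)c1C#N` differs from compound 3 by pyridin-3-yl in place of pyridin-4-yl on a carbonyl carbon. No measured step bears on this move of the ring nitrogen, and the one step at the carbonyl carbon is unreadable, so the direction and size of the change cannot be read from the shown compounds. Compound 4 is therefore expected to stay close to where compound 3 sits, with a step of a number no higher from compound 3 to compound 4 (the limit leaves the size open) that may well remain hidden at the limit. The estimate for compound 4 in this assay is 5000 nM, between 1500 nM and 15000 nM.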

Compound 4, half-maximal inhibitory concentration: > 5000 nM
Compound 4: no number, only a limit; the forecaster's own chance of this, stated with the estimate: 60%; the middle value lies on the limit itself.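

In this assay compound 4 gives only a limit, > 5000 nM. Neither step to compound 4, from compound 1 or from compound 3, can be read, because both ends of each rest on the same limit: the limit of > 5000 nM in this assay, at which 3 of the 4 values shown sit. The compounds shown leave open whether pyridin-3-yl and pyridin-4-yl on a carbonyl carbon differ at all.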